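The compounds below may be only part of what the source reports. "The series", "measured", "known", "first", "only" and "open" are said of these compounds alone.

Compound 1 `CCCCCCCOc1ccc(CCC(N)(CO)CO)cc1` — 0.049 mg/kg
Compound 2 `CCCCCCCCc1ccc(CCC(N)(CO)C(=O)O)cc1` — > 10 mg/kg

Of the compounds shown here, two have been measured in a functional assay on the whole organism (spleen, spleen) with Rattus norvegicus as the target; a higher number here means that more compound is needed for the effect, a lower number that less compound is needed. Compound 1 has the structure `CCCCCCCOc1ccc(CCC(N)(CO)CO)cc1` and in this assay compound 1 gives 0.049 mg/kg. Compound 2, with the structure `CCCCCCCCc1ccc(CCC(N)(CO)C(=O)O)cc1`, stands at the far end of what has been seen: in this assay compound 2 is reported only as a limit, > 10 mg/kg, and not as a number. Going by these compounds, that is the limit of > 10 mg/kg in this assay, at which 1 of the 2 values shown sits, so where compound 2 truly lies past that bound is unknown. Next to it stands compound 3, `CCCCCCCCc1ccc(CCC(N)CO)cc1`, which has not yet been measured. Compound 3 differs from compound 2 in a single place: hydrogen in place of carboxy on a saturated chain carbon bound to an amine nitrogen and two saturated chain carbons. Going by the values given here, no step between measured compounds is available to size this change, and compound 1 differs from both in more than one place, so it cannot serve as a direct comparison. A move in this assay well beyond the scatter, toward less compound being needed, is nonetheless expected for compound 3. Compound 3 is estimated at 0.5 mg/kg, with a range from 0.1 mg/kg to 3 mg/kg, which corresponds to an expected step of an at least 20-fold lower number from compound 2 to compound 3 (1.30 log units; beyond the scatter).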

Compound 3, dose for 50% inhibition: > 10 mg/kg
Compound 3 ended at the assay's limit; the forecaster's own chance of this, stated with the estimate: 15%; middle value at least 20-fold (1.30 log units) away from the limit.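

Compound 2 and compound 3 both carry only a limit in this assay, not a number, so no step between them can be read: the limit of > 10 mg/kg in this assay, at which 2 of the 3 values shown sit.

The compounds shown leave open where compound 2 and compound 3 truly lie past that limit, and whether hydrogen in place of carboxy changes the amount of compound needed at all.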